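Dropping one methoxy from a trimethoxyphenyl cyclopentenone series

This account rests on a few compounds, and the source may have more. Where it says the series, first, only, none or still open, it means among the compounds named here.

Compound 1 `COc1ccc(C2=C(c3cc(OC)c(OC)c(OC)c3)C(=O)CC2O[SiH2]C(C)(C)C)cc1OC` gives > 100 ug/mL in an ADME assay on MIA PaCa-2 cells (Homo sapiens) for cytotoxicity, read by MTT assay, with a stated time of 72 h; a lower number here means a stronger inhibitor, a higher number a weaker inhibitor.
Compound 2 `COc1ccc(C2=C(c3cc(OC)c(OC)c(OC)c3)CC(O)C2=O)cc1[N+](=O)[O-]` gives > 100 ug/mL in this assay.
Compound 3 `COc1ccc(C2=C(c3cc(OC)c(OC)c(OC)c3)C(=O)C(OC(C)=O)C2)cc1` gives < 1 ug/mL in this assay.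

For compound 1 only a limit is known, the one at the limit of > 100 ug/mL in this assay, at which 2 of the 3 values shown sit, so its true value is not a number. The same limit covers compound 2. Compound 3 sits at the other limit, (the limit of < 1 ug/mL in this assay, at which 1 of the 3 values shown sits). Compound 4 `COc1ccc(C2=C(c3cc(OC)c(OC)c(OC)c3)C(=O)CC2O[SiH2]C(C)(C)C)cc1` is the next step: hydrogen in place of methoxy on an aromatic carbon. Since compound 1 is known only as a limit, the size of any step from it cannot be set against the scatter with confidence; a gain in potency is expected rather than none, but its size is open. Compound 4 is estimated at 20 ug/mL, between 3 ug/mL and 100 ug/mL, which means an expected step of an at least 5.0-fold lower number from compound 1 to compound 4 (0.69 log units; beyond the scatter).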

Compound 4, half-maximal inhibitory concentration: > 100 ug/mL
Compound 4 gave a limit, no number; the forecaster's own chance of this, stated with the estimate: 40%; middle value at least 5.0-fold (0.69 log units) away from the limit.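

In this assay compound 4 gives > 100 ug/mL, a limit and not a number. Among the compounds shown here, compound 1 sits at the same limit, > 100 ug/mL, so no step from compound 1 to compound 4 can be read. From the compounds shown here alone, whether hydrogen in place of methoxy on an aromatic carbon changes potency at all stays open.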